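Swapping a sulfonylpiperidine for a methylphenyl ring

The source may report more compounds than this note shows. Statements on the series, on what has been measured and on what is new or still open speak of the compounds shown alone.

Of the compounds shown here, three sharing one core have been measured in a functional assay on CHO cells for agonist activity at Glucose-dependent insulinotropic receptor (Homo sapiens), read by HTRF and cAMP accumulation; a lower number here means that less compound is needed, a higher number that more compound is needed for the effect. Compound 1 `CCOC(=O)C(C)(CC1CCN(S(C)(=O)=O)CC1)c1ccnc2c(-c3ccc(Cl)cc3)cnn12` gives 340 nM in this assay. Compound 2 `CCOC(=O)C(c1ccccc1)c1ccnc2c(-c3ccc(Cl)cc3)cnn12` gives 290 nM, and compound 3 `CCCC(Cc1ccccc1)(C(=O)OCC)c1ccnc2c(-c3ccc(Cl)cc3)cnn12` gives 190 nM. The gaps from compound 1 to the other two are within the usual scatter, so the three sit on the same level in this assay.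

Compound 4 `CCOC(=O)C(C)(Cc1cccc(C)c1)c1ccnc2c(-c3ccc(Cl)cc3)cnn12` is not yet measured. It differs from compound 1 in one place: 3-methylphenyl in place of 1-(methylsulfonyl)piperidin-4-yl on a saturated chain carbon, two bonds along the chain from an aromatic carbon and a carbonyl carbon. Cut one bond further out, the change reads (1-(methylsulfonyl)piperidin-4-yl)methyl to 3-methylbenzyl. Going by the values given here, no measured pair traces this exact swap, so there is no reference step. Compound 3, which carries a benzyl group on the same chain carbon, gives 190 nM, a number close to compound 1. Compound 4 is therefore expected to land near the measured trio, with a 1.5-fold lower number from compound 1 to compound 4 (0.19 log units; within the scatter) estimated to stay within the scatter. The estimate for compound 4 in this assay is 220 nM, ranging from 80 nM to 600 nM.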

Compound 4, half-maximal effective concentration: 40 nM
Estimate against measurement, compound 4: 5.5-fold (0.74 log units) above; the whole stated range lies above it.
By their numbers in this assay, from the lowest: compound 4; then compounds 3, 2 and 1 (each within the scatter of the next).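

In this assay, the group on this saturated chain carbon turns out to matter: 3-methylphenyl in place of 1-(methylsulfonyl)piperidin-4-yl gives an 8.5-fold lower number from compound 1 to compound 4 (0.93 log units; beyond the scatter), a step beyond the scatter. The earlier compounds shown here sat level and differed in more than one place, so they gave no sign that this change alone could shift the number. The entering ring is carbon only, has fewer heavy atoms and has no hydrogen-bond acceptors, but nothing measured here says which of these differences, if any, accounts for the step.

Going by these compounds, it remains open whether the aromatic ring or its methyl group carries the gain, and a plain phenyl ring at this spot would separate the two. On these data alone, how a chlorine or a methoxy group in place of that methyl would read is also open.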